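A few compounds are considered here, and "the series" means these few. Any claim that something is new, unique, unknown or untested is made for them only; others in the source may bear on it.

Measured in a functional assay on A2780 cells (Homo sapiens) for inhibition, read by sulforhodamine B assay, with a stated time of 72 h; a higher number here means a weaker inhibitor, a lower number a stronger inhibitor:
- compound 1 `O=C(NCc1ccc(S(=O)(=O)c2ccccc2)cc1)c1cc2ncccc2s1`: > 10000 nM (a limit)
- compound 2 `Cn1c(C(=O)NCc2ccc(S(=O)(=O)c3ccccc3)cc2)cc2cnccc21`: > 10000 nM (a limit)

Compound 2 gives > 10000 nM in this assay, which is a limit and not a number. Among the compounds with values here, the whole picture so far is the limit of > 10000 nM in this assay, at which 2 of the 2 values shown sit, so no measured step is available to size any change.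

Next in line is compound 3 `O=C(NCc1ccc(S(=O)(=O)c2ccccc2)cc1)c1cc2cnccc2[nH]1`, with hydrogen in place of methyl on an aromatic nitrogen, next to the ring atom that bears a large group (hydrogen in place of methyl on an aromatic nitrogen).

This is a small structural change, but the expectation here is a large move toward stronger inhibition, as a judgement only: an at least 250-fold lower number from compound 2 to compound 3 (2.39 log units; beyond the scatter). A further result at the limit remains possible.

For compound 3 the estimated value is 40 nM, with an expected range of 3 nM to 3000 nM.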

Compound 3, half-maximal inhibitory concentration: 18 nM
Beside the measured number, compound 3's estimate is 2.2-fold (0.35 log units) above it, within the range that was stated.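

In this assay the aromatic nitrogen of the five-membered ring, next to the ring atom that bears a large group, proves decisive among these compounds: hydrogen in place of methyl there gives an at least 550-fold lower number from compound 2 to compound 3 (2.74 log units; beyond the scatter). Within the data shown here, exchanging the group on the carbonyl carbon of compound 1 for that of compound 3 gives an at least 550-fold lower number from compound 1 to compound 3 (2.74 log units; beyond the scatter), so among the three compounds only the one with hydrogen on that aromatic nitrogen gives a number rather than a limit. Both steps are minimum sizes, not exact ones, since they start from limits: the limit of > 10000 nM in this assay, at which 2 of the 3 values shown sit.

On these data alone, the true size of each step stays open, as does whether the hydrogen itself is required, and an ethyl or acetyl group on that nitrogen would not settle this alone. Also open, as far as these compounds go, is how far the phenyl sulfonyl part can change, for example with an amine on its terminal ring.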